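This account rests on a few compounds, and the source may have more. Where it says the series, first, only, none or still open, it means among the compounds named here.

In a functional assay on KG-1 cells (Homo sapiens) for cytotoxicity, read by luminescence and CellTiter-Glo, with a stated time of 3 days (a higher number here means a weaker inhibitor, a lower number a stronger inhibitor), compound 1 `O=C(Nc1ccc(C(F)(F)F)cc1)c1cc(Cl)ccc1O` gives 740 nM, compound 2 `O=C(Nc1ccc(C(F)(F)F)cc1)c1cc(F)ccc1O` gives 1700 nM, and compound 3 `O=C(Nc1ccc(C(F)(F)F)cc1)c1cc(Br)c(F)cc1O` gives 820 nM. Compound 3 therefore lies within the scatter of compound 1, while compound 2 has a higher number than compound 3, beyond the scatter. Compound 4 `O=C(Nc1ccc(C(F)(F)F)cc1)c1cc(Br)ccc1O` differs from compound 3 by hydrogen in place of fluoro on an aromatic carbon, with hydrogen in place of fluoro on an aromatic carbon, ortho to a bromo group. For the measured compounds named here, no measured pair shows this exact change. The nearest evidence is a modest halogen swap, a 2.3-fold higher number from compound 1 to compound 2 (0.36 log units; beyond the scatter), with fluoro in place of chloro. In this assay, only a small change is therefore expected, probably none beyond the scatter and with no firm direction. The expected step is a 1.2-fold lower number from compound 3 to compound 4 (0.07 log units; within the scatter). For compound 4, the estimated value is 700 nM, with an expected range from 350 nM to 1400 nM.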

Compound 4, half-maximal inhibitory concentration: 610 nM
Estimate against measurement, compound 4: 1.1-fold (0.06 log units) above; the measured number falls inside the stated range.
By their numbers in this assay, from the lowest: compounds 4, 1 and 3 (each within the scatter of the next); then compound 2.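

In this assay, hydrogen in place of fluoro, ortho to a bromo group, leaves the number essentially unchanged (a 1.3-fold lower number from compound 3 to compound 4 (0.13 log units; within the scatter)), so this position accepts either atom. At the halogen position of the shared core, bromo and chloro cannot be told apart (a 1.2-fold lower number from compound 1 to compound 4 (0.08 log units; within the scatter)), while bromo in place of fluoro gives a real drop (a 2.8-fold lower number from compound 2 to compound 4 (0.45 log units; beyond the scatter)). Nothing available explains these numbers.

Open, as far as these compounds go, is whether an amine or a methoxy group at the position that held fluoro would leave the number unchanged. Also open, from the compounds shown here alone, is how a nitrile in place of the bromo group would compare.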